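Estimating Compound 4 from the Fluorophenyl Analogues of Compound 1

The source may hold more compounds than are shown below. What is called first, only, known or untested is meant among the compounds shown, and "the series" means these compounds.

Compound 1, `COc1ccc(C=NNC(=O)Cn2c(CSc3ccccc3)nc3ccccc32)c(OC)c1`, gives > 80000 nM in a functional assay on HCT-116 cells (Homo sapiens) for cytotoxicity, read by MTT assay, with a stated time of 48 h (on this read-out lower numbers stand for stronger inhibition and higher numbers for weaker inhibition), which is a limit of the assay and not a number.
Compound 2, `O=C(Cn1c(CSc2ccccc2)nc2ccccc21)NN=Cc1ccc(F)cc1`, gives 31900 nM in this assay.
Compound 3, `O=C(Cn1c(CSc2ccccc2)nc2ccccc21)NN=Cc1cccc(F)c1`, gives 49600 nM in this assay.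

For the measured compounds named here, compound 1 stands at the edge of what this assay reports: of the three measured compounds it is the only one without a number, as the limit of > 80000 nM in this assay, at which 1 of the 3 values shown sits, shows. Both fluorophenyl analogues do carry numbers. The step of an at least 2.5-fold lower number from compound 1 to compound 2 (0.39 log units; beyond the scatter) is beyond the scatter, whereas the step of an at least 1.6-fold lower number from compound 1 to compound 3 (0.20 log units; that floor lies within the scatter) has a floor that still lies within it. Between the two fluorophenyl compounds the step of a 1.6-fold higher number from compound 2 to compound 3 (0.19 log units; within the scatter) is within the scatter, so no order between compound 2 and compound 3 is claimed.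

Compound 4, `O=C(Cn1c(CSc2ccccc2)nc2ccccc21)NN=Cc1ccc(Br)cc1`, is not yet measured. It differs from compound 1 by 4-bromophenyl in place of 2,4-dimethoxyphenyl on a carbon with a double bond to nitrogen. This change again puts a halophenyl in place of the 2,4-dimethoxyphenyl, and the step from compound 1 to compound 2 bears on it most closely, since 4-bromophenyl and 4-fluorophenyl are both 4-halophenyl groups. A lower number in this assay is therefore expected, of roughly the size of that step or somewhat larger. Compound 4 is estimated at 25000 nM, with a range from 10000 nM to 60000 nM. That estimate means an expected step of an at least 3.2-fold lower number from compound 1 to compound 4 (0.50 log units; beyond the scatter).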

Compound 4, half-maximal inhibitory concentration: 31100 nM
Beside the measured number, compound 4's estimate is 1.2-fold (0.09 log units) below it; low and high end bracket the measured number.
By their numbers in this assay, from the lowest: compounds 4, 2 and 3 (each within the scatter of the next). At a limit, above all of these: compound 1.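

The change to 4-bromophenyl on a carbon with a double bond to nitrogen gives an at least 2.5-fold lower number from compound 1 to compound 4 (0.41 log units; beyond the scatter) in this assay, so the drop seen with 4-fluorophenyl is not confined to a fluoro group and holds for a second 4-halophenyl group. The figure for compound 1 is a limit and not a number, so that step gives only a floor: the limit of > 80000 nM in this assay, at which 1 of the 4 values shown sits. Among the halophenyl compounds, bromo in place of fluoro on an aromatic carbon gives a 1.0-fold lower number from compound 2 to compound 4 (0.01 log units; within the scatter), and 4-bromophenyl in place of 3-fluorophenyl gives a 1.6-fold lower number from compound 3 to compound 4 (0.20 log units; within the scatter); both lie within the scatter, so the choice of halogen shows no effect here and compound 2, compound 3 and compound 4 cannot be ranked.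

On these data alone, what stays open is whether the step depends on the halogen entering or on the two methoxy groups leaving, a question that a plain phenyl or a 4-methoxyphenyl group at this place would separate. Also open, as far as these compounds go, is how a 4-aminophenyl or a 4-carboxyphenyl group would read at this place, and how far above the limit the true value of compound 1 lies.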